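The source may hold more compounds than are shown below. What is called first, only, known or untested is meant among the compounds shown, and "the series" means these compounds.

Compound 1 `COc1ccc(-c2[nH]c3ccccc3c2/C=C(\C#N)S(=O)(=O)c2ccccc2)cc1` stands lowest of the two numbers measured here: in a functional assay on HT-29 cells (Homo sapiens) for inhibition, read by sulforhodamine B assay, with a stated time of 48 h (on this read-out lower numbers stand for stronger inhibition of growth and higher numbers for weaker inhibition of growth), compound 1 gives 314 nM, whereas compound 2 `CCOC(=O)C(=Cc1c(-c2ccccc2)[nH]c2ccccc12)C(=O)OCC` gives 4600 nM, a far higher number on the same read-out. Compound 3 `COc1ccc(-c2[nH]c3ccc(OC)cc3c2/C=C(\C#N)S(=O)(=O)c2ccccc2)cc1` differs from compound 1 by methoxy in place of hydrogen on an aromatic carbon, so that a second methoxy now sits on the shared core. Among the compounds with values here, no pair of measured compounds shows this change, so no step for it is known. For compound 3 the step of a 1.0-fold lower number from compound 1 to compound 3 (0.02 log units; within the scatter) is expected to be small, in either direction, and not beyond the scatter. Compound 3 is estimated at 300 nM, within 100 nM to 900 nM.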

Compound 3, concentration for 50% growth inhibition: 435 nM
Compound 3: the middle estimate sits 1.5-fold (0.16 log units) below what was measured; the range from low to high includes it.
By their numbers in this assay, from the lowest: compounds 1 and 3 (each within the scatter of the next); then compound 2.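

In this assay, methoxy in place of hydrogen on an aromatic carbon of the shared core gives a 1.4-fold higher number from compound 1 to compound 3 (0.14 log units; within the scatter) and so leaves the growth inhibition unchanged within the scatter. Within the data shown here, this is the first step known at this position, which carries the methoxy without a measurable loss. Nothing at hand explains this result. From the compounds shown here alone, whether the position would accept other groups stays open, since a single methoxy says nothing about a chlorine atom, an amine or a carboxylic acid there.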